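Removing a Methyl From Compound 2 in a Griess Inhibition Assay

The source may report more compounds than this note shows. Statements on the series, on what has been measured and on what is new or still open speak of the compounds shown alone.

Three related compounds have been tested so far. Compound 1 `COc1cc(/C(Cl)=C/C=C(\C#N)C(=O)c2c[nH]c3ccccc23)cc(OC)c1OC`, compound 2 `COc1ccc(/C(Cl)=C/C=C(\C#N)C(=O)c2c(C)[nH]c3ccccc23)cc1` and compound 3 `COc1ccc2[nH]cc(C(=O)/C(C#N)=C/C=C(\Cl)c3ccc(Br)cc3)c2c1` share one core and differ in the groups around it. In a functional assay for inhibition, read by Griess assay, with a stated time of 150 min, tested at 1 mM (on this read-out higher numbers stand for more inhibition at the one concentration tested (going by the name of the read-out) and lower numbers for less inhibition), compound 1 gives 73.3%, compound 2 gives 74%, and compound 3 gives 76.7%. Compound 2 stands second highest of the three numbers, but its nearest neighbour compound 1 and its furthest neighbour compound 3 both lie within the usual scatter of it, so the three values are best read as one level.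

Compound 4 `COc1ccc(/C(Cl)=C/C=C(\C#N)C(=O)c2c[nH]c3ccccc23)cc1` has not yet been measured in this assay. It differs from compound 2 in a single place: hydrogen in place of methyl on an aromatic carbon. Going by the values given here, no pair of measured compounds differing in only one place is available, so the size of this step cannot be read from a comparison. Compound 1 and compound 3, which also carry hydrogen at that carbon, sit at the same level as compound 2, which speaks against any large move.

Compound 4 is therefore expected to give 74% in this assay, with a range of 62% to 86%. The expected step of no change at the digits printed from compound 2 to compound 4 (within the scatter) is estimated to stay within the scatter.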

Compound 4, a percentage reported as inhibition, at one concentration (the size of the read-out at that concentration, not a potency): 76.9%
Compound 4: middle estimate off by 2.9 percentage points, on the low side; measured number inside the range.
By their numbers in this assay, from the lowest: compounds 1, 2, 3 and 4 (each within the scatter of the next).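

In this assay, going by these compounds alone, the pair gives the first direct reading of a change at this position: hydrogen in place of methyl on this aromatic carbon gives a number 2.9 percentage points higher from compound 2 to compound 4 (within the scatter). At the one concentration tested, then, the methyl is not needed for this pair to hold its level of inhibition, although a reading at a single concentration is not a potency and could miss a difference that a full dose series might show. Nothing available here offers an explanation for this result.

The compounds shown leave open whether an ethyl group, a longer chain, an amine or a carboxylic acid on this carbon would move the read-out beyond the scatter. They also leave open whether the step stays this small when the groups elsewhere on the shared core differ, as they do in compound 1 and compound 3.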